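Methylating the phenolic hydroxyl of a benzoxazole sulfonamide

A few compounds are considered here, and "the series" means these few. Any claim that something is new, unique, unknown or untested is made for them only; others in the source may bear on it.

Measured compounds:
Compound 1, `O=S(=O)(Nc1ccc2oc(-c3ccccc3)nc2c1)c1ccccc1O`, gives 85000 nM.
Compound 2, `O=S(=O)(Nc1ccc(-c2nc3cc(NS(=O)(=O)c4ccccc4O)ccc3o2)cc1)c1ccccc1O`, gives 18000 nM.
Compound 3, `O=S(=O)(Nc1ccc(-c2nc3ccccc3o2)cc1)c1ccc(Cl)s1`, gives 31000 nM.

These three compounds were tested in an assay on cells for inhibition of HSP60/HSP10 (Homo sapiens), with a stated time of 60 min; on this read-out higher numbers stand for weaker inhibition and lower numbers for stronger inhibition. Among them compound 1 stands with the highest number: compound 3 sits below it, and compound 2 sits further below it still. For the measured compounds named here, the one single-place step among the measured compounds is a 4.7-fold lower number from compound 1 to compound 2 (0.67 log units; beyond the scatter), which adds a second sulfonyl amino group to the shared core rather than touching the existing one.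

Compound 4, `COc1ccccc1S(=O)(=O)Nc1ccc2oc(-c3ccccc3)nc2c1`, differs from compound 1 by methyl in place of hydrogen on an oxygen on an aromatic ring. Going by the values given here, no measured step bears directly on this change: the step from compound 1 to compound 2 concerns a different place, and compound 3 differs from compound 1 in more than one place, so its value shows only that a different aryl sulfonyl group gives a somewhat lower number. Among the compounds with values here, with no comparable step available, the expectation for this assay is a change that stays within the scatter, with a slight lean toward a higher number, and the estimated step is a 1.2-fold higher number from compound 1 to compound 4 (0.07 log units; within the scatter). Compound 4 is therefore expected to give about 100000 nM, within a range from 40000 nM to 250000 nM.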

Compound 4, half-maximal inhibitory concentration: > 100000 nM
Compound 4: only a limit was reported; the forecaster's own chance of this, stated with the estimate: 30%; the middle value sits exactly at the limit.
By their numbers in this assay, from the lowest: compounds 2 and 3 (each within the scatter of the next); then compound 1. At a limit, above all of these: compound 4.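

In this assay compound 4 is reported only as a limit, > 100000 nM. This is the first change among the compounds shown that touches the hydroxy group itself: replacing hydroxy with methoxy gives an at least 1.1-fold higher number from compound 1 to compound 4 (0.07 log units; that floor lies within the scatter), so placing methyl on this oxygen brings no measurable gain in inhibition, although the floor of the step does not by itself show a loss. Whether the true step lies beyond the scatter cannot be told, because the reading for compound 4 ends at a limit: the limit of > 100000 nM in this assay, at which 1 of the 4 values shown sits.

As far as these compounds go, what remains open is how far this place tolerates anything other than hydroxy or methoxy, since an amine, a fluorine or a longer chain on the oxygen such as ethoxy would each test it differently from methyl. For the compounds shown here, also open is whether the same change would carry over to compound 2, which gives 18000 nM and holds two 2-hydroxyphenyl groups, and whether methylating one of these would matter more or less than it does on the single group of compound 1.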